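A Second Methyl on the Carboxyethyl Arm

The source may report more compounds than this note shows. Statements on the series, on what has been measured and on what is new or still open speak of the compounds shown alone.

Of the compounds shown here, three have been measured in a functional assay on CHO cells for antagonist activity at sphingosine 1-phosphate receptor 2 (Homo sapiens), read by GTPgammaS binding; a lower number here means a stronger inhibitor, a higher number a weaker inhibitor. Compound 1 `O=C(O)Cn1nc(Cc2nc3cc(Cl)c(OCC(F)F)cc3[nH]2)c2ccccc2c1=O` gives 15 nM. Compound 3 `CCOc1cc2[nH]c(Cc3nn(CC(=O)N4CCOCC4)c(=O)c4ccccc34)nc2cc1Cl` gives 22 nM. Compound 2 `C[C@@H](C(=O)O)c1nn(Cc2cn3cc(OCC4CC4)c(Cl)cc3n2)c2ccccc2c1=O` gives 253 nM, the highest of the three numbers and so the weakest inhibitor among them; its gap to compound 3 and its gap to compound 1 both lie beyond the usual scatter of repeated measurements.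

Compound 4 `CC(C)(C(=O)O)c1nn(Cc2cn3cc(OCC4CC4)c(Cl)cc3n2)c2ccccc2c1=O` has not yet been measured. It differs from compound 2 in one place: 1-carboxy-1-methylethyl in place of 1-carboxyethyl on an aromatic carbon. The group that leaves carries 1 defined stereocentre; the group that enters carries none and has one more heavy atom.

Going by the values given here, no pair of measured compounds differs in only one place, so there is no measured step of this kind to lean on. The change is small in size, and compound 2 already stands as the weakest of the three measured compounds. The step from compound 2 to compound 4 is expected to be a 1.2-fold higher number from compound 2 to compound 4 (0.07 log units; within the scatter), which may well fall within the scatter, in either direction. Compound 4 is therefore expected to give about 300 nM in this assay, with a likely range from 100 nM to 900 nM.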

Compound 4, half-maximal inhibitory concentration: 105 nM
Beside the measured number, compound 4's estimate is 2.9-fold (0.46 log units) above it; the range from low to high includes it.
By their numbers in this assay, from the lowest: compounds 1 and 3 (each within the scatter of the next); then compound 4; then compound 2.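

In this assay the swap of 1-carboxyethyl for 1-carboxy-1-methylethyl brings a 2.4-fold lower number from compound 2 to compound 4 (0.38 log units; beyond the scatter) and this modest step lies beyond the scatter. Going by these compounds alone, it is the first comparison in this set between two compounds that differ in one place, and it shows that this aromatic carbon, next to the ring nitrogen, accepts the group with one more heavy atom without any loss of inhibition, and that the defined stereocentre of compound 2 is not required for activity. Nothing measured here accounts for the gain, and the reason for it remains unknown.

This is a single step on a single core, so it cannot say whether the same swap would help on the core of compound 1 or compound 3, and the mirror-image form of compound 2 is absent from the compounds shown, which leaves the role of the stereocentre's direction unsettled. From the compounds shown here alone, it is also open how the arm would respond to a cyclopropane ring carrying the carboxylic acid, to a longer chain between the ring and the acid, or to a tetrazole in place of the carboxylic acid.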